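This account rests on a few compounds, and the source may have more. Where it says the series, first, only, none or still open, it means among the compounds named here.

Measured in a functional assay on SNB-19 cells (Homo sapiens) for inhibition, read by sulforhodamine B assay, with a stated time of 48 h, tested at 10 uM; a lower number here means less inhibition, a higher number more inhibition at the concentration tested (going by the name of the read-out):
Compound 1 `Brc1cn2ccnc2c(-c2ccc3ncn(C4CCCCC4)c3c2)n1` gives 8.09%.
Compound 2 `Fc1ccccc1-c1cn2ccnc2c(-c2ccc3ncn(C4CCCCC4)c3c2)n1` gives 7.56%.
Compound 3 `CCc1ccc(-c2cn3ccnc3c(-c3ccc4ncn(Cc5ccccc5)c4c3)n2)cc1` gives 20.9%.

Compound 3 stands highest of the three numbers, and its lead over compound 1 and over compound 2 lies beyond the usual scatter of this measurement. Compound 4 `Cc1cccc(-c2cn3ccnc3c(-c3ccc4ncn(Cc5ccccc5)c4c3)n2)c1` differs from compound 3 in one place: 3-methylphenyl in place of 4-ethylphenyl on an aromatic carbon. Among the measured compounds shown here, the only measured step, a number 0.5 percentage points lower from compound 1 to compound 2 (within the scatter), concerns a different place on the shared core and a different kind of exchange, so it offers no direct guidance here. For the measured compounds named here, with no comparable step in hand, the expected step of a number 3.9 percentage points lower from compound 3 to compound 4 (within the scatter) in this assay is small, not beyond the scatter. Compound 4 is therefore expected to give 17%, within a range from 5% to 30%.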

Compound 4, a percentage reported as inhibition, at one concentration (the size of the read-out at that concentration, not a potency): 2.58%
Compound 4: the middle estimate sits 14.4 percentage points above what was measured, and the stated range ends above it.
By their numbers in this assay, from the lowest: compounds 4, 2 and 1 (each within the scatter of the next); then compound 3.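

In this assay, putting 3-methylphenyl in place of 4-ethylphenyl on this aromatic carbon gives a number 18.3 percentage points lower from compound 3 to compound 4 (beyond the scatter), the first clear change seen for a single exchange on the shared core. Both groups are carbon-only phenyl rings with no hydrogen-bond donors or acceptors, so even a small change to the group at this place can shift the read-out. No measurement here explains this drop. The two groups differ in both the chain and where it sits on the phenyl ring, and these two changes cannot be separated here. On these data alone, how an amine or a carboxylic acid on that phenyl ring would behave also remains open.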